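The source may report more compounds than this note shows. Statements on the series, on what has been measured and on what is new or still open speak of the compounds shown alone.

Measured compounds in this series:
- compound 1 `Cc1ccc(C(=O)CSc2nnc(C)n2N2C(=O)c3ccccc3C2=O)cc1`
- compound 2 `Cc1nnc(SCC(=O)c2ccccc2)n1N1C(=O)c2ccccc2C1=O`
- compound 3 `Cc1nnc(SCc2ccccc2Cl)n1N1C(=O)c2ccccc2C1=O`

In a functional assay on PC-3M cells (Homo sapiens) for cytotoxicity, read by MTT assay, with a stated time of 48 h (on this read-out lower numbers stand for stronger inhibition and higher numbers for weaker inhibition), compound 1 gives > 200000 nM, a limit of the assay and not a number. Compound 2 likewise gives > 200000 nM, a limit. Compound 3 gives > 200000 nM, again a limit. So compound 1 stands only at a limit, as do the other two (the limit of > 200000 nM in this assay, at which 3 of the 3 values shown sit).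

Compound 4 `CCc1nnc(SCC(=O)c2ccc(C)cc2)n1N1C(=O)c2ccccc2C1=O` differs from compound 1 by methyl in place of hydrogen on a saturated chain carbon bound to an aromatic carbon. Among the compounds with values here, no measured step carries this change. The nearest comparison, a step that the two limits leave unreadable from compound 1 to compound 2, removes rather than adds a methyl and cannot be read; a step that the two limits leave unreadable from compound 1 to compound 3 and a step that the two limits leave unreadable from compound 2 to compound 3 are equally unreadable. No step size can therefore be drawn from the data, and no shift beyond the scatter is expected in either direction. Compound 4 is estimated at 300000 nM, within 100000 nM to 2000000 nM. This estimate means an expected step that the limit leaves unreadable from compound 1 to compound 4.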

Compound 4, half-maximal inhibitory concentration: > 200000 nM
Compound 4 was reported as a limit; the forecaster's own chance of this, stated with the estimate: 85%; the middle value lies beyond the limit too.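

Compound 1 and compound 4 both stand only at a limit, so no step between them can be read: the limit of > 200000 nM in this assay, at which 4 of the 4 values shown sit.

The compounds shown leave open how the four rank and which change to the shared core, if any, would give a measurable value.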